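Trifluoromethyl shift on the sulfonyl sulfur substituent

A few compounds are considered here, and "the series" means these few. Any claim that something is new, unique, unknown or untested is made for them only; others in the source may bear on it.

In a functional assay on DU-145 cells (Homo sapiens) for antiproliferative activity, read by propidium iodide staining, with a stated time of 96 h (on this read-out lower numbers stand for stronger inhibition and higher numbers for weaker inhibition), compound 1 (`CC(O)(CS(=O)(=O)c1cccc(S(F)(F)(F)(F)F)c1)C(=O)Nc1ccc(S(F)(F)(F)(F)F)cc1`) gives 34000 nM and compound 2 (`CC(O)(CS(=O)(=O)c1ccc(C(F)(F)F)cc1)C(=O)Nc1ccc(S(F)(F)(F)(F)F)cc1`) gives 29300 nM and so lies within the scatter of compound 1. The two values therefore set no order. Compound 3 (`CC(O)(CS(=O)(=O)c1cccc(C(F)(F)F)c1)C(=O)Nc1ccc(S(F)(F)(F)(F)F)cc1`) is not yet measured. It differs from compound 2 in one place, with 3-(trifluoromethyl)phenyl in place of 4-(trifluoromethyl)phenyl on a sulfonyl sulfur. The two have the same atoms, joined differently. Going by the values given here, no step between measured compounds is available to size this change. The expectation therefore starts from compound 2 at 29300 nM and no shift beyond the scatter is expected in either direction. The expected step is small (a 1.0-fold higher number from compound 2 to compound 3 (0.01 log units; within the scatter)). Compound 3 is estimated at 30000 nM with 13000 nM to 60000 nM as the expected range.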

Compound 3, half-maximal inhibitory concentration: 31900 nM
For compound 3 the middle estimate is 1.1-fold (0.03 log units) below the measured one; the range from low to high includes it.
By their numbers in this assay, from the lowest: compounds 2, 3 and 1 (each within the scatter of the next).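

In this assay 3-(trifluoromethyl)phenyl in place of 4-(trifluoromethyl)phenyl on a sulfonyl sulfur gives a 1.1-fold higher number from compound 2 to compound 3 (0.04 log units; within the scatter) and so does not separate the two isomers. Trifluoromethyl in place of pentafluorosulfanyl on an aromatic carbon gives a 1.1-fold lower number from compound 1 to compound 3 (0.03 log units; within the scatter) and provides the first single-place comparison of these two groups, which also remain unseparated. Nothing measured here accounts for the small size of either step.

Open, going by these compounds, is whether a carboxylic acid or an aminomethyl group in place of the trifluoromethyl on this aromatic ring would give a step beyond the scatter. On these data alone, the group on the amide nitrogen is the same in all three compounds, so its contribution to the read-out also remains open.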